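Swapping one methoxy for hydrogen on compound 1

A few compounds are considered here, and "the series" means these few. Any claim that something is new, unique, unknown or untested is made for them only; others in the source may bear on it.

- Compound 1 (`COc1cc(C(=O)/C=C\Nc2ccc(-c3nc4cc(OC)c(OC)c(OC)c4s3)cc2C)cc([N+](=O)[O-])c1OC`): 17400 nM
- Compound 2 (`COc1cc(C(=O)/C=C\Nc2ccc(-c3nc4cc(OC)c(OC)c(OC)c4s3)cc2)c(Br)c(OC)c1OC`): 13600 nM

In a functional assay on A549 cells (Homo sapiens) for antiproliferative activity, read by sulforhodamine B assay, with a stated time of 48 h (a higher number here means a weaker inhibitor, a lower number a stronger inhibitor), compound 1 and compound 2 lie within the usual scatter of each other, so these two numbers cannot rank them. Going by the values given here, compound 1 therefore stands level with the only other measured compound, and two values show no trend.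

Compound 3 (`COc1ccc(C(=O)/C=C\Nc2ccc(-c3nc4cc(OC)c(OC)c(OC)c4s3)cc2C)cc1[N+](=O)[O-]`) has not been measured yet. It differs from compound 1 in one place, with hydrogen in place of methoxy on an aromatic carbon. Among the compounds with values here, no measured pair shows what this swap does. The expectation in this assay is a step no larger than the scatter, with no favoured direction, although the uncertainty is wide. For compound 3 the estimated value is 14000 nM, with an expected range from 5000 nM to 40000 nM. That estimate means an expected 1.2-fold lower number from compound 1 to compound 3 (0.09 log units; within the scatter).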

Compound 3, half-maximal inhibitory concentration: 9100 nM
Compound 3: middle estimate off by 1.5-fold (0.19 log units), on the high side, and the stated range covers the measured number.
By their numbers in this assay, from the lowest: compounds 3, 2 and 1 (each within the scatter of the next).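

Going by these compounds alone, this is the first pair in the set that differs in one place, so the effect of a single swap can now be read directly. In this assay, putting hydrogen in place of methoxy on an aromatic carbon, ortho to a methoxy group and meta to a nitro group, gives a 1.9-fold lower number from compound 1 to compound 3 (0.28 log units; within the scatter), so this pair shows no measurable difference between the two groups at this place. Nothing measured here offers an explanation for this outcome.

With only hydrogen and methoxy shown at this place, it remains open whether a hydroxyl, an amine or a longer chain such as ethoxy would give a number beyond the scatter. A single pair also leaves open whether the same swap would behave alike on a different part of the molecule.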